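Swapping Fluoro for Nitro on an Aromatic Carbon

This account rests on a few compounds, and the source may have more. Where it says the series, first, only, none or still open, it means among the compounds named here.

Among the measured compounds shown here, in a functional assay on MCF7 cells (Homo sapiens) for cytotoxicity, read by MTT assay, with a stated time of 48 h (on this read-out higher numbers stand for weaker inhibition and lower numbers for stronger inhibition), compound 3 (`C/C(=N\NC(=S)Nc1ccccc1F)c1ccccn1`) gives 0.39 nM and stands level with compound 1 (`C/C(=N/NC(=S)Nc1ccccc1F)c1ccccn1`) at 0.39 nM as the higher of the numbers so far, while compound 2 (`C/C(=N\NC(=S)Nc1ccccc1Cl)c1ccccn1`) gives 0.16 nM and so shows stronger inhibition than compound 3.

Compound 4 (`C/C(=N\NC(=S)Nc1ccccc1[N+](=O)[O-])c1ccccn1`) has not yet been measured. It carries nitro in place of fluoro on an aromatic carbon, ortho to a large group (nitro in place of fluoro on an aromatic carbon).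

Two measured steps can be weighed here. Because of the fact that compounds 1 and 3 differ only in the configuration as drawn the comparison showing no change at the digits printed from compound 1 to compound 3 (within the scatter) says nothing about a new group on the ring. The more useful guide is the swap between compound 2 and compound 3, which gave a 2.4-fold higher number from compound 2 to compound 3 (0.39 log units; beyond the scatter) and counts as modest. For the measured compounds named here, no nitro compound has been measured, so the direction of the coming step cannot be read from these data. Going by that single modest swap, a large move is not expected, and the best guess is no step beyond the scatter. What is estimated is a small step, a 1.3-fold lower number from compound 3 to compound 4 (0.11 log units; within the scatter) and no more. In this assay the expected value for compound 4 is 0.3 nM with an estimated range from 0.1 nM to 1 nM as a wide allowance for so few neighbours.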

Compound 4, half-maximal inhibitory concentration: 5.7 nM
For compound 4 the middle estimate is 19-fold (1.28 log units) below the measured one; measured number outside the range, above it.
By their numbers in this assay, from the lowest: compound 2; then compounds 1 and 3 (each within the scatter of the next); then compound 4.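

In this assay, among the compounds shown here, this place on the aromatic ring proves far from indifferent to the group it carries: nitro in place of fluoro gives a large step (a 15-fold higher number from compound 3 to compound 4 (1.16 log units; beyond the scatter)), whereas the only earlier swap of groups here, fluoro in place of chloro, was modest (a 2.4-fold higher number from compound 2 to compound 3 (0.39 log units; beyond the scatter)). Nitro in place of chloro gives a larger step still (a 36-fold higher number from compound 2 to compound 4 (1.55 log units; beyond the scatter)), so compound 4 stands well above both compound 2 and compound 3, and the modest swap between the two halogens gave no hint of a move this size. Nothing measured here gives a reason for the size of this step.

From the compounds shown here alone, whether the jump belongs to nitro alone stays open, and an amine, a methoxy group or a nitrile at the same place would help to show whether other groups bring a similar rise. Also open, going by these compounds, are whether the drawn configuration of the double bond matters as little with nitro as it does for the fluoro pair, compound 1 and compound 3, and whether nitro would act the same way elsewhere on the ring.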